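A few compounds are considered here, and "the series" means these few. Any claim that something is new, unique, unknown or untested is made for them only; others in the source may bear on it.

Compound 1 `CC[C@H]1c2cc(Cl)ccc2C(=O)N1c1cncc2c1CCC[C@H]2NC(C)=O` is assessed in an ADME assay on microsomes from liver (Homo sapiens) for metabolic stability, read by LC-MS, using NADPH, with stated times of 10 min and 30 min; on this read-out lower numbers stand for slow clearance and higher numbers for fast clearance. In this assay compound 1 gives only a limit, < 3.5 mL/min/kg. Compound 2 `CC(=O)N[C@@H]1CCCc2c1cncc2N1C(=O)c2ccc(Cl)cc2[C@H]1C` likewise returns a limit, < 3.5 mL/min/kg. Compound 3 `CC1CN(c2cccnc2)C(=O)c2ccc(Cl)cc21` gives a measured value of 6.6 mL/min/kg. Compound 1 thus sits at the limit of < 3.5 mL/min/kg in this assay, at which 2 of the 3 values shown sit, and the numbers shown give no step between measured compounds. Compound 4 `CCC(=O)N[C@@H]1CCCc2c1cncc2N1C(=O)c2ccc(Cl)cc2[C@@H]1CC` differs from compound 1 by methyl in place of hydrogen on a saturated chain carbon bound to a carbonyl carbon. Among the measured compounds shown here, with no measured step to lean on, the change is expected to matter little, shifting clearance slightly toward faster if at all: an at least 1.2-fold higher number from compound 1 to compound 4 (0.10 log units; that floor lies within the scatter). Compound 4 is therefore estimated to show a clearance of 4.5 mL/min/kg, between 2.5 mL/min/kg and 9 mL/min/kg, with a fair chance that the assay again reports only a limit.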

Compound 4, clearance: < 3.5 mL/min/kg
Compound 4: only a limit was reported; the forecaster's own chance of this, stated with the estimate: 45%; middle value at least 1.2-fold (0.10 log units) from the limit.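

In this assay compound 1 and compound 4 both return only a limit, so no step between them can be read: the limit of < 3.5 mL/min/kg in this assay, at which 3 of the 4 values shown sit.

The compounds shown leave open whether propanoylamino in place of acetamido changes clearance at all.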